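Swapping methyl for nitro on a benzyl ether inhibitor

The source may report more compounds than this note shows. Statements on the series, on what has been measured and on what is new or still open speak of the compounds shown alone.

Two close relatives share one core: compound 1, `CC(=O)c1ccc(OCc2ccccc2C)cc1`, and compound 2, `CC(=O)c1ccc(OCc2cccc(C)c2)cc1`. In an assay on isolated protein for inhibition of Amine oxidase [flavin-containing] B (Homo sapiens), read by Amplex Red, with a stated time of 15 min (on this read-out lower numbers stand for stronger inhibition and higher numbers for weaker inhibition), compound 1 gives 77.1 nM, and compound 2 gives 86.3 nM, the higher of the two numbers, though the gap to compound 1 lies within the scatter. Compound 3, `CC(=O)c1ccc(OCc2cccc([N+](=O)[O-])c2)cc1`, differs from compound 2 by nitro in place of methyl on an aromatic carbon. Within the data shown here, no measured pair shows this change, so no step beyond the scatter is expected in this assay, and the estimated step of a 1.2-fold higher number from compound 2 to compound 3 (0.06 log units; within the scatter) reflects that. Compound 3 is expected to give about 100 nM, within 30 nM to 330 nM.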

Compound 3, half-maximal inhibitory concentration: 104 nM
For compound 3 the middle estimate is 1.0-fold (0.02 log units) below the measured one, within the range that was stated.
By their numbers in this assay, from the lowest: compounds 1, 2 and 3 (each within the scatter of the next).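

Nitro in place of methyl on an aromatic carbon, meta to a large group, gives a 1.2-fold higher number from compound 2 to compound 3 (0.08 log units; within the scatter) in this assay. At this position, the two groups cannot be told apart on this read-out, although nitro brings hydrogen-bond acceptors and methyl has none. No other measurement shown bears on why they read alike. From the compounds shown here alone, whether an amine or a carboxylic acid at this position would also read alike stays open. So does whether nitro would match methyl at the place the methyl occupies in compound 1.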